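Trading Methoxyphenyl for Chlorophenyl in Mice

The source may report more compounds than this note shows. Statements on the series, on what has been measured and on what is new or still open speak of the compounds shown alone.

Compound 1 `O=c1oc2cccnc2n1CCN1CCN(c2ccc(F)cc2)CC1` — 41.3 mg/kg
Compound 2 `COc1ccccc1N1CCN(Cn2c(=O)oc3cccnc32)CC1` — > 25 mg/kg
Compound 3 `O=c1oc2ccccc2n1CCN1CCN(c2ccccc2)CC1` — > 50 mg/kg

All three were tested in a functional assay on the whole organism with Mus musculus as the target; on this read-out lower numbers stand for an effect already at smaller amounts and higher numbers for an effect only at larger amounts of compound. Compound 1 gives 41.3 mg/kg. For compound 2 the read-out is only a limit of the assay, > 25 mg/kg. For compound 3 as well only a limit is reported, > 50 mg/kg. Compound 2 therefore stands at a bound rather than at a number, one of two such bounds among the three values (the limit of > 25 mg/kg in this assay, at which 1 of the 3 values shown sits), and it cannot be placed above or below compound 1.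

Compound 4 `O=c1oc2cccnc2n1CN1CCN(c2ccc(Cl)cc2)CC1` is not yet measured. It keeps the core of compound 2 and differs from it in one place: 4-chlorophenyl in place of 2-methoxyphenyl on an amine nitrogen in a ring. Among the measured compounds shown here, no measured pair isolates this change, so no step size is known from which to argue. Given that a bound is the starting point, only a small move in this assay is expected, or none beyond the scatter. The implied step that the limit leaves unreadable from compound 2 to compound 4 is thus expected to be modest. Compound 4 is expected to give 40 mg/kg (range 15 mg/kg to 110 mg/kg).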

Compound 4, dose for half-maximal effect: 10.6 mg/kg
Compound 4: the middle estimate sits 3.8-fold (0.58 log units) above what was measured; measured number below the stated range.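

In this assay, placing 4-chlorophenyl where 2-methoxyphenyl stood, on an amine nitrogen in a ring, gives an at least 2.3-fold lower number from compound 2 to compound 4 (0.37 log units; beyond the scatter). This is the first pair among the compounds shown that isolates a change at this position, and it shows that the group carried on this nitrogen can shift the effect to smaller doses by more than the usual scatter. Compound 2 holds only a limit, so this step marks a minimum and not a full size: the limit of > 25 mg/kg in this assay, at which 1 of the 4 values shown sits.

The swap removes the methoxy group and brings in the chlorine in a single move, so this one pair cannot show which of the two matters, or whether the place of each on the phenyl ring does. It also leaves open how this assay would respond to a nitrile or a trifluoromethyl group in place of the chlorine.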